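Replacing 1-hydroxy-1-methylethyl with methylsulfonyl on compound 3

This account rests on a few compounds, and the source may have more. Where it says the series, first, only, none or still open, it means among the compounds named here.

Compound 1 `COc1cc(OCc2csc(-c3ccc(C(F)(F)F)cc3)n2)c2cc(-c3cn4nc(OC)sc4n3)oc2c1` gives 726 ng.h/mL
Compound 2 `COc1cc(OCc2cccc(-c3ccc(OC)nc3)c2)c2cc(-c3cn4nc(OC)sc4n3)oc2c1` gives 1800 ng.h/mL
Compound 3 `COc1cc(OCc2csc(-c3ccc(C(C)(C)O)cc3)n2)c2cc(-c3cn4nc(OC)sc4n3)oc2c1` gives 505 ng.h/mL

In an ADME assay on the whole organism (Rattus norvegicus), at a dose of 2 mg/kg by the oral route (on this read-out higher numbers stand for higher exposure at the dose given and lower numbers for lower exposure), compound 3 stands within the scatter of compound 1, while compound 2 lies beyond the scatter above it. Compound 4 `COc1cc(OCc2csc(-c3ccc(S(C)(=O)=O)cc3)n2)c2cc(-c3cn4nc(OC)sc4n3)oc2c1` differs from compound 3 at one place, with methylsulfonyl in place of 1-hydroxy-1-methylethyl on an aromatic carbon. Among the measured compounds shown here, the only measured step at that place (a 1.4-fold lower number from compound 1 to compound 3 (0.16 log units; within the scatter)) stayed within the scatter, though it involved a different pair of groups. No step beyond the scatter is therefore expected in this assay for this change. The expected step (a 1.1-fold higher number from compound 3 to compound 4 (0.04 log units; within the scatter)) is accordingly small. Compound 4 is estimated at 550 ng.h/mL with an expected range from 180 ng.h/mL to 1600 ng.h/mL at this dose.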

Compound 4, area under the concentration-time curve: 148 ng.h/mL
For compound 4 the middle estimate is 3.7-fold (0.57 log units) above the measured one; the measured number lies below the stated range.
By their numbers in this assay, from the lowest: compound 4; then compounds 3 and 1 (each within the scatter of the next); then compound 2.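

In this assay this position proves sensitive to the group it carries: methylsulfonyl gives a 3.4-fold lower number from compound 3 to compound 4 (0.53 log units; beyond the scatter) and a 4.9-fold lower number from compound 1 to compound 4 (0.69 log units; beyond the scatter), whereas trifluoromethyl and 1-hydroxy-1-methylethyl had stayed within the scatter of each other. Of the three groups compared here, only methylsulfonyl moves the number beyond the scatter. Nothing shown bears on why the number falls.

From the compounds shown here alone, whether an amine, a carboxylic acid or a sulfonamide here would stay with compound 1 and compound 3 or fall with compound 4 remains open. So does whether the lower exposure would persist at other doses.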